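Swapping a Cyclopentyl for a 2-Fluorophenyl Group

A few compounds are considered here, and "the series" means these few. Any claim that something is new, unique, unknown or untested is made for them only; others in the source may bear on it.

Compound 1, `COc1cc(N)c(Cl)cc1NC(=O)C1CCN(C2CCCC2)CC1`: > 10 mg/kg
Compound 2, `COc1cc(N)c(Cl)cc1NC(=O)C1CCN(Cc2cccc(C)c2)CC1`: 2.4 mg/kg
Compound 3, `COc1cc(N)c(Cl)cc1NC(=O)C1CCN(CC2CCCC2)CC1`: > 10 mg/kg

Three compounds share one core and differ only in the group carried on the amine nitrogen in the ring. In a functional assay on the whole organism for antagonist activity, with Mus musculus as the target (a higher number here means that more compound is needed for the effect, a lower number that less compound is needed), compound 3 gives > 10 mg/kg, which is a limit of the assay rather than a number. Compound 1 also sits at a limit, giving > 10 mg/kg in this assay. Only compound 2 returns a number, 2.4 mg/kg in this assay.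

Compound 4, `COc1cc(N)c(Cl)cc1NC(=O)C1CCN(Cc2ccccc2F)CC1`, has not yet been measured. Its change from compound 3 is 2-fluorophenyl in place of cyclopentyl on a saturated chain carbon bound to an amine nitrogen in a ring.

Going by the values given here, one measured step bears directly on this change: an at least 4.1-fold higher number from compound 2 to compound 3 (0.61 log units; beyond the scatter). The move from compound 3 to compound 4 runs that step the other way, putting an aromatic ring back where the cyclopentyl stood, though with a fluorine in place of a methyl. The step of an at least 4.1-fold lower number from compound 1 to compound 2 (0.61 log units; beyond the scatter) points the same way, an aromatic group giving a lower number than a saturated ring. A step in the direction of a lower number is therefore expected: an at least 3.3-fold lower number from compound 3 to compound 4 (0.52 log units; beyond the scatter). Compound 4 is expected to give 3 mg/kg in this assay, with a range from 1 mg/kg to 10 mg/kg.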

Compound 4, dose for half-maximal effect: > 4 mg/kg
Compound 4: only a limit was reported (the forecaster's own chance of this, stated with the estimate: 20%); middle value at least 1.3-fold (0.12 log units) from the limit.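

In this assay compound 4 gives > 4 mg/kg, which is a limit of the assay and not a number. Putting an aromatic ring back on the saturated chain carbon bound to the amine nitrogen in the ring has therefore not been shown to be enough to give a measured dose, and the comparison with the 3-methylphenyl group is only an at least 1.6-fold higher number from compound 2 to compound 4 (0.22 log units; that floor lies within the scatter), so a real difference between these two aromatic groups is not established. The steps to compound 4 from compound 1 and from compound 3 cannot be read, because each joins two limits: the limit of > 10 mg/kg in this assay, at which 2 of the 4 values shown sit.

The compounds shown leave open how far beyond its limit the true dose of compound 4 lies, and so whether 2-fluorophenyl truly differs from 3-methylphenyl or from cyclopentyl at this place. A plain benzyl group, a 2-methylbenzyl group and a 3-fluorobenzyl group on the same nitrogen would help to separate the part played by the fluorine from the part played by where the group sits on the ring.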